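Adding a trifluoromethyl group to the fluorophenyl end of the chain

The source may report more compounds than this note shows. Statements on the series, on what has been measured and on what is new or still open speak of the compounds shown alone.

Compound 2 `CC1=C(/C=C/C(=O)/C=C/c2ccc(F)cc2)C(C)(C)CCC1O`: 7500 nM
Compound 1 `CC1=C(/C=C/C(=O)/C=C/c2cccc(C(F)(F)F)c2)C(C)(C)CCC1O`: 1700 nM

In a functional assay on CWR22R cells (Homo sapiens) for cytotoxicity, read by MTT assay, with a stated time of 72 h (a lower number here means a stronger inhibitor, a higher number a weaker inhibitor), compound 2 gives 7500 nM, the highest of the two numbers shown; the nearest is compound 1, whose value in this assay, 1700 nM, lies beyond the scatter below it. Compound 3 `CC1=C(/C=C/C(=O)/C=C/c2ccc(F)c(C(F)(F)F)c2)C(C)(C)CCC1O` differs from compound 2 by trifluoromethyl in place of hydrogen on an aromatic carbon. Going by the values given here, no measured pair shows this exact step, so the expectation rests on what the two values show: compound 1 carries a trifluoromethyl on the same kind of ring and gives the lower number. For compound 3 a step towards a lower number in this assay is therefore expected, of a size beyond the scatter, a 3.8-fold lower number from compound 2 to compound 3 (0.57 log units; beyond the scatter). Compound 3 is thus estimated at 2000 nM, with a range from 700 nM to 6000 nM.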

Compound 3, half-maximal inhibitory concentration: 3200 nM
Beside the measured number, compound 3's estimate is 1.6-fold (0.20 log units) below it; the measured number falls inside the stated range.
By their numbers in this assay, from the lowest: compounds 1 and 3 (each within the scatter of the next); then compound 2.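

In this assay, trifluoromethyl in place of hydrogen on an aromatic carbon ortho to a fluoro group gives a 2.3-fold lower number from compound 2 to compound 3 (0.37 log units; beyond the scatter) and so still lowers the number, modestly, with the fluoro group kept on the ring. Fluoro in place of hydrogen on the ring of compound 1 gives a 1.9-fold higher number from compound 1 to compound 3 (0.27 log units; within the scatter) and stays within the scatter, so once trifluoromethyl is present, this added fluoro group makes no difference that this assay can separate. Nothing available here explains either step.

As far as these compounds go, whether another group at this position, such as a nitrile, a methoxy group or an amine, would give a lower number remains open. So does whether the hydroxyl group on the shared core matters, for instance if an amine or a methoxy group stood in its place.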